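This account rests on a few compounds, and the source may have more. Where it says the series, first, only, none or still open, it means among the compounds named here.

Three compounds in this series share one core and differ only in the group on the far aromatic ring. Compound 1 `CC1(C)OB(c2ccc(COc3ccc(CNC(=O)[C@@H]4CCC(=O)N4Cc4ccccc4)cc3)cc2)OC1(C)C` carries a boronate ester there, and in an assay on HEK293 cells for inhibition of Ataxin-2 (Mus musculus), read by fluorescence and Amplex Red (a lower number here means a stronger inhibitor, a higher number a weaker inhibitor), compound 1 gives 50 nM. Compound 2 `O=C(O)c1ccc(COc2ccc(CNC(=O)[C@@H]3CCC(=O)N3Cc3ccccc3)cc2)cc1` carries a carboxylic acid, and in this assay compound 2 gives 4500 nM. Compound 3 `O=C(NO)c1ccc(COc2ccc(CNC(=O)[C@@H]3CCC(=O)N3Cc3ccccc3)cc2)cc1` carries a hydroxamic acid, and in this assay compound 3 gives 700 nM. Compound 3 thus stands second highest of the three numbers, nearest to compound 2 and furthest from compound 1. The measured steps are a 90-fold higher number from compound 1 to compound 2 (1.95 log units; beyond the scatter), a 14-fold higher number from compound 1 to compound 3 (1.15 log units; beyond the scatter), and a 6.4-fold lower number from compound 2 to compound 3 (0.81 log units; beyond the scatter).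

Compound 4 `O=C(NCc1ccc(OCc2ccc(-c3nn[nH]n3)cc2)cc1)[C@@H]1CCC(=O)N1Cc1ccccc1` has not yet been measured. Its change from compound 3 is 2H-tetrazol-5-yl in place of hydroxycarbamoyl on an aromatic carbon. Within the data shown here, no measured step covers this exact exchange. The step that bears most is a 6.4-fold lower number from compound 2 to compound 3 (0.81 log units; beyond the scatter), showing that swapping one small group for another on the same aromatic carbon moves the number modestly, while a 90-fold higher number from compound 1 to compound 2 (1.95 log units; beyond the scatter) and a 14-fold higher number from compound 1 to compound 3 (1.15 log units; beyond the scatter) show that the large losses belong to leaving the boronate ester. Compound 4 is therefore expected to fall between the numbers of compound 2 and compound 3, an estimated 1500 nM in this assay, ranging from 400 nM to 6000 nM. That expected shift is a 2.1-fold higher number from compound 3 to compound 4 (0.33 log units; beyond the scatter).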

Compound 4, half-maximal inhibitory concentration: > 5000 nM
Compound 4 was reported as a limit; the forecaster's own chance of this, stated with the estimate: 5%; middle value at least 3.3-fold (0.52 log units) away from the limit.
By their numbers in this assay, from the lowest: compound 1; then compound 3; then compound 2. At a limit, above all of these: compound 4.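

Compound 4 is reported only as a limit of the assay, not as a number: the limit of > 5000 nM in this assay, at which 1 of the 4 values shown sits.

On this aromatic carbon, para to a large group, 2H-tetrazol-5-yl does not hold the level that hydroxycarbamoyl gives in this assay, with an at least 7.1-fold higher number from compound 3 to compound 4 (0.85 log units; beyond the scatter), so the earlier swap among small groups does not predict a modest shift for every small group here. Against the carboxylic acid the result is less clear: an at least 1.1-fold higher number from compound 2 to compound 4 (0.04 log units; that floor lies within the scatter) does not order the two. Meanwhile an at least 100-fold higher number from compound 1 to compound 4 (2.00 log units; beyond the scatter) adds a third small group that stands far from the boronate ester.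

The compounds shown leave open how far the number of compound 4 actually lies beyond its limit, and whether any other small group on this carbon, such as a sulfonamide or a primary amide, can come closer to compound 1. They also leave open whether the low number of compound 1 belongs to boron itself or to the whole pinacol ring, a question that a free boronic acid at the same place would address.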